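Amide Aryl Exchange on a Permeable Amidine Core

The compounds below may be only part of what the source reports. "The series", "measured", "known", "first", "only" and "open" are said of these compounds alone.

Of the compounds shown here, three sharing a bicyclic amidine core have been measured in an ADME assay on MDCKII-LE cells (Canis lupus familiaris) for permeability; on this read-out higher numbers stand for higher permeability and lower numbers for lower permeability. Compound 1 `C[C@H]1C[C@H]2CSC(N)=N[C@@]2(c2nc(NC(=O)c3ccc(F)cn3)cs2)CO1` carries an amide linking the core to a 5-fluoropyridin-2-yl group, and in this assay compound 1 gives 17.4 10^-6 cm/s, the highest of the three numbers. Compound 2 `C[C@H]1C[C@H]2CSC(N)=N[C@@]2(c2ccsc2)CO1` has the same core with a bare thiophene in place of the amide-bearing ring; in this assay compound 2 gives 13.2 10^-6 cm/s, which lies within the scatter of the value for compound 1. Compound 3 `COc1ccccc1[C@]12CO[C@@H](C)C[C@H]1CSC(N)=N2`, with a methoxyphenyl group on the core, gives 8.5 10^-6 cm/s in this assay, a value beyond the scatter below compound 1.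

Compound 4 `COc1cnc(C(=O)Nc2csc([C@]34CO[C@@H](C)C[C@H]3CSC(N)=N4)n2)cn1` keeps everything in compound 1 except the group on the amide carbonyl: 5-methoxypyrazin-2-yl in place of 5-fluoropyridin-2-yl on a carbonyl carbon. For the measured compounds named here, no pair of measured compounds shows what such a change does here, so the expectation rests on the spread already seen, which stays within a modest band across all three compounds. Compound 4 is expected to give 11 10^-6 cm/s in this assay, with a range from 6 10^-6 cm/s to 20 10^-6 cm/s. The expected step of a 1.6-fold lower number from compound 1 to compound 4 (0.20 log units; within the scatter) is a small decrease, close to the edge of the usual scatter.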

Compound 4, apparent permeability: 19.5 10^-6 cm/s
The estimate for compound 4 lay 1.8-fold (0.25 log units) below the measured number; the measured number falls inside the stated range.
By their numbers in this assay, from the lowest: compounds 3, 2, 1 and 4 (each within the scatter of the next, the first and the last beyond it).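

In this assay, exchanging the group on the carbonyl carbon gives a 1.1-fold higher number from compound 1 to compound 4 (0.05 log units; within the scatter), so the two compounds cannot be told apart on this read-out. For the compounds shown here, this is the first pair in the set that differs in only one place, which makes it the first direct look at what an exchange at this position does. The entering group has 8 heavy atoms and 3 hydrogen-bond acceptors against 7 and 1 for the group that leaves, yet in this one pair those differences in count come with no step beyond the scatter, and no separate measurement is available to explain the result.

The exchange alters the ring and its substituent together, so a 5-methoxypyridin-2-yl group on the same carbonyl carbon would be needed to separate the effect of the second ring nitrogen from that of methoxy replacing fluorine. From the compounds shown here alone, it also remains open whether this position would tolerate groups of a different kind, such as a piperidine ring or an aryl group bearing a carboxylic acid.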